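Benzyl ether series: nitro to ethoxy on the pendant ring

A few compounds are considered here, and "the series" means these few. Any claim that something is new, unique, unknown or untested is made for them only; others in the source may bear on it.

Compound 3 `COc1cccc(OC)c1OCCNCCOc1ccccc1OCc1ccc([N+](=O)[O-])cc1` sits at the high end of the three measured benzyl ethers: in a functional assay on PC-3 cells (Homo sapiens) for cytotoxicity, read by sulforhodamine B assay (on this read-out higher numbers stand for weaker inhibition of growth and lower numbers for stronger inhibition of growth), compound 3 gives 43600 nM. Compound 2 `COc1cccc(OC)c1OCCNCCOc1ccccc1OCc1cccc(C)c1` gives 32300 nM in this assay, and the two lie within the scatter of each other, as a 1.3-fold higher number from compound 2 to compound 3 (0.13 log units; within the scatter) shows. Compound 1 `COc1cccc(OC)c1OCCNCCOc1ccccc1OCc1ccc(Cl)cc1` gives 14500 nM in this assay, the lowest number of the three; both a 3.0-fold higher number from compound 1 to compound 3 (0.48 log units; beyond the scatter) and a 2.2-fold higher number from compound 1 to compound 2 (0.35 log units; beyond the scatter) lie beyond the scatter.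

Compound 4 `CCOc1ccc(COc2ccccc2OCCNCCOc2c(OC)cccc2OC)cc1` differs from compound 3 by ethoxy in place of nitro on an aromatic carbon. For the measured compounds named here, only one measured step changes the group on this same aromatic carbon, para to a large group: a 3.0-fold higher number from compound 1 to compound 3 (0.48 log units; beyond the scatter), a modest step. Going by the values given here, no measured compound carries an ethoxy on this ring, so the direction of the new step is not fixed by the data; the three measured compounds span a modest range in this assay in all.

The expected step in this assay from compound 3 is therefore small, a 1.5-fold lower number from compound 3 to compound 4 (0.16 log units; within the scatter), leaning toward a lower number only because compound 1 gives 14500 nM with chloro at this place. For compound 4 the estimate in this assay is 30000 nM, with a range from 10000 nM to 90000 nM.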

Compound 4, concentration for total growth inhibition: 18200 nM
Compound 4: the middle estimate sits 1.6-fold (0.22 log units) above what was measured; measured number inside the range.
By their numbers in this assay, from the lowest: compounds 1, 4, 2 and 3 (each within the scatter of the next, the first and the last beyond it).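

In this assay, nitro now stands apart from two other groups on this aromatic carbon, para to a large group: besides the earlier step from chloro, a 2.4-fold lower number from compound 3 to compound 4 (0.38 log units; beyond the scatter) also lies beyond the scatter, so the gap to compound 3 does not rest on chloro alone. Ethoxy and chloro cannot be told apart here, since a 1.3-fold higher number from compound 1 to compound 4 (0.10 log units; within the scatter) lies within the scatter, even though the two groups differ in their atoms and ethoxy carries two carbons. The 3-methylphenyl compound cannot be separated from the 4-ethoxyphenyl compound either, as a 1.8-fold lower number from compound 2 to compound 4 (0.25 log units; within the scatter) also lies within the scatter, so the series does not fall into two clean groups: compound 2 is beyond the scatter from compound 1 yet within it from compound 4. Nothing available explains why nitro stands apart from chloro and ethoxy.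

Open, from the compounds shown here alone, is how an amine or a carboxylic acid on this carbon would read, and whether a longer chain such as butoxy would stay with ethoxy. Also open, going by these compounds, is whether ethoxy on the 3-position of the ring would read like 4-ethoxyphenyl.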